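The source may report more compounds than this note shows. Statements on the series, on what has been measured and on what is new or still open speak of the compounds shown alone.

Measured compounds:
Compound 1, `CCCSc1nc(Cl)c2c(n1)N(Cc1ccccc1)C(C(=O)OCC)N2`: 62500 nM
Compound 2, `CCCSc1nc(Cl)c2c(n1)N(Cc1ccccc1)C(C(=O)N1CCN(C)CC1)N2`: 29800 nM

Both were tested in a functional assay on PC-3 cells (Homo sapiens) for antiproliferative activity, read by MTT assay, with a stated time of 72 h; on this read-out lower numbers stand for stronger inhibition and higher numbers for weaker inhibition. Compound 1 gives 62500 nM, and compound 2 gives 29800 nM, the lowest of the two numbers and so the stronger inhibitor of the pair. The step of a 2.1-fold lower number from compound 1 to compound 2 (0.32 log units; beyond the scatter) came from putting 4-methylpiperazin-1-yl in place of ethoxy on a carbonyl carbon.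

Compound 3, `CCCSc1nc(Cl)c2c(n1)N(Cc1ccccc1)C(C(=O)NCCCc1ccccc1)N2`, has not yet been measured. It differs from compound 2 on that same carbonyl carbon: (3-phenylpropyl)amino in place of 4-methylpiperazin-1-yl on a carbonyl carbon. Among the compounds with values here, the only measured step, a 2.1-fold lower number from compound 1 to compound 2 (0.32 log units; beyond the scatter), concerns a different exchange at this carbonyl carbon and shows that swapping the group there moved the number only modestly. Within the data shown here, no measured pair shows what a (3-phenylpropyl)amino group on this carbonyl carbon does, so the evidence for compound 3 is thin. A step in this assay of modest size at most is expected, in either direction, and quite possibly within the scatter. Compound 3 is therefore expected to come in near 20000 nM, within a range from 6000 nM to 60000 nM. This estimate means a step of a 1.5-fold lower number from compound 2 to compound 3 (0.17 log units; within the scatter).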

Compound 3, half-maximal inhibitory concentration: 12700 nM
Compound 3: middle estimate off by 1.6-fold (0.20 log units), on the high side; the range from low to high includes it.
By their numbers in this assay, from the lowest: compound 3; then compound 2; then compound 1.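

In this assay, the carbonyl carbon now carries a third kind of group, and (3-phenylpropyl)amino gives the lowest number of the set, with a 2.3-fold lower number from compound 2 to compound 3 (0.37 log units; beyond the scatter) and a 4.9-fold lower number from compound 1 to compound 3 (0.69 log units; beyond the scatter) as its two steps. This shows that, among these three groups, the ring-bearing amide with 4-methylpiperazin-1-yl is not the best choice: an open chain ending in an aromatic ring does better than both it and ethoxy, although both steps are still modest. The swap from compound 2 to compound 3 changes several things at once, replacing a non-aromatic ring holding two nitrogens with a chain that ends in a carbon-only aromatic ring and brings in an amide hydrogen, and no available evidence ties the lower number to any one of these features.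

A plain propylamino group, without the phenyl ring, would help separate the contribution of the ring from that of the chain. A shorter benzylamino group or a longer chain leading to the same phenyl ring would show whether the length of the chain matters at this carbonyl carbon.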